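The compounds below may be only part of what the source reports. "The series", "measured", "known", "first", "only" and "open" are said of these compounds alone.

Compound 1, `O=C1C(NC2CCCC2)=CC(=O)c2c1nc1n2[C@H]2OC[C@@H](O)[C@H]2OC1`, gives > 16000 nM in a functional assay on MCF7 cells (Homo sapiens) for inhibition, read by sulforhodamine B assay; a higher number here means a weaker inhibitor, a lower number a stronger inhibitor; this is a limit.
Compound 2, `O=C1C(NC2CCCCC2)=CC(=O)c2c1nc1n2[C@H]2OC[C@@H](O)[C@H]2OC1`, gives > 16000 nM in this assay; this is a limit.
Compound 3, `CCCN(CCC)C1=CC(=O)c2nc3n(c2C1=O)[C@H]1OC[C@@H](O)[C@H]1OC3`, gives > 16000 nM in this assay; this is a limit.

Compound 2 therefore stands at the limit of > 16000 nM in this assay, at which 3 of the 3 values shown sit, with no number of its own. For the measured compounds named here, the one measured step, a step that the two limits leave unreadable from compound 1 to compound 2, stays unreadable because the limit of > 16000 nM in this assay, at which 3 of the 3 values shown sit, covers both of its ends. Compound 4, `O=C1C(Nc2cccc(F)c2)=CC(=O)c2c1nc1n2[C@H]2OC[C@@H](O)[C@H]2OC1`, differs from compound 2 by 3-fluorophenyl in place of cyclohexyl on an amine nitrogen. Going by the values given here, no measured step speaks to an aromatic ring on this amine nitrogen, so nothing readable bears on the change. Compound 4 is expected to give 12000 nM, between 2000 nM and 50000 nM. The step of an at least 1.3-fold lower number from compound 2 to compound 4 (0.12 log units; that floor lies within the scatter) is thus only an estimate, most likely ending again at a limit.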

Compound 4, half-maximal inhibitory concentration: > 4000 nM
Compound 4: only a limit was reported; the forecaster's own chance of this, stated with the estimate: 60%; the middle value is on the limit's open side.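

In this assay compound 4 gives > 4000 nM, which is a limit, so the steps to it from compound 1 and compound 2 cannot be read. The compounds shown leave open whether 3-fluorophenyl in place of cyclohexyl on this amine nitrogen changes inhibition at all.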